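Swapping the Aryl Group at the Amine-Bearing Carbon

A few compounds are considered here, and "the series" means these few. Any claim that something is new, unique, unknown or untested is made for them only; others in the source may bear on it.

Compound 1, `COc1ccc(CNCCCNS(=O)(=O)c2cc(C(F)(F)F)cc(C(F)(F)F)c2)cc1OC`: 6400 nM
Compound 2, `O=S(=O)(NCCCNCC1COc2ccccc2O1)c1cc(C(F)(F)F)cc(C(F)(F)F)c1`: 2900 nM

Of the two numbers measured in a functional assay on ASPC1 cells (Homo sapiens) for inhibition, read by MTT assay, with a stated time of 72 h (a higher number here means a weaker inhibitor of growth, a lower number a stronger inhibitor of growth), compound 2 holds the lowest; its nearest neighbour is compound 1, separated from it by a 2.2-fold lower number from compound 1 to compound 2 (0.34 log units; beyond the scatter). Compound 3, `O=S(=O)(NCCCNCc1ccc(C(F)(F)F)cc1)c1cc(C(F)(F)F)cc(C(F)(F)F)c1`, has not yet been measured in this assay. It differs from compound 2 by 4-(trifluoromethyl)phenyl in place of 2,3-dihydro-1,4-benzodioxin-2-yl on a saturated chain carbon bound to an amine nitrogen. Among the compounds with values here, only one measured step speaks to this position: the change from compound 1 to compound 2, also a swap of the aryl group on that carbon, gave a 2.2-fold lower number from compound 1 to compound 2 (0.34 log units; beyond the scatter), a modest shift. Within the data shown here, no step with a trifluoromethyl-bearing aryl group at this place has been measured, so the direction is open. Compound 3 is therefore expected to give about 3000 nM in this assay, within a range of 1200 nM to 8000 nM. This estimate means a step of a 1.0-fold higher number from compound 2 to compound 3 (0.01 log units; within the scatter), expected to stay within the scatter.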

Compound 3, concentration for 50% growth inhibition: 2000 nM
Estimate against measurement, compound 3: 1.5-fold (0.18 log units) above; measured number inside the range.
By their numbers in this assay, from the lowest: compounds 3 and 2 (each within the scatter of the next); then compound 1.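

In this assay, 4-(trifluoromethyl)phenyl on a saturated chain carbon bound to an amine nitrogen gave a 1.5-fold lower number from compound 2 to compound 3 (0.16 log units; within the scatter), so a group carrying no oxygen matches 2,3-dihydro-1,4-benzodioxin-2-yl here, and the oxygen atoms of that group are not needed to reach this level. The same group in place of 3,4-dimethoxyphenyl gave a 3.2-fold lower number from compound 1 to compound 3 (0.51 log units; beyond the scatter), which leaves compound 1 alone apart from the other two, with both steps to it beyond the scatter. No evidence available here explains these numbers.

Going by these compounds, whether the trifluoromethyl group contributes anything beyond the phenyl ring carrying it stays open, and a plain phenyl or a 4-chlorophenyl group on this carbon would test that. Also open, on these data alone, is how a pyridine ring here, or a longer chain in the shared core, would shift the number.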